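This account rests on a few compounds, and the source may have more. Where it says the series, first, only, none or still open, it means among the compounds named here.

Working notes on the series. Three analogues share a core and differ only in the group on a saturated chain carbon bound to an amine nitrogen. In a functional assay on MIA PaCa-2 cells (Homo sapiens) for inhibition, read by MTT assay, with a stated time of 72 h (a higher number here means a weaker inhibitor of growth, a lower number a stronger inhibitor of growth), compound 1 `COc1ccc(CNCCCNS(=O)(=O)c2cc(C(F)(F)F)cc(C(F)(F)F)c2)cc1OC` gives 2800 nM, compound 2 `O=S(=O)(NCCCNCC1COc2ccccc2O1)c1cc(C(F)(F)F)cc(C(F)(F)F)c1` gives 2600 nM and compound 3 `O=S(=O)(NCCCNCc1ccc(Br)cc1)c1cc(C(F)(F)F)cc(C(F)(F)F)c1` gives 2300 nM. Compound 3 carries the lowest of the three numbers, but its nearest neighbour is compound 2 and its furthest is compound 1, both within the scatter, so no ordering among the three can be claimed.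

The next step, from compound 3 to compound 4 `O=S(=O)(NCCCNCc1cccc2ccccc12)c1cc(C(F)(F)F)cc(C(F)(F)F)c1`, is naphthalen-1-yl in place of 4-bromophenyl on a saturated chain carbon bound to an amine nitrogen. Each earlier step at this same position bears on it: a 1.1-fold lower number from compound 1 to compound 2 (0.03 log units; within the scatter), a 1.2-fold lower number from compound 1 to compound 3 (0.09 log units; within the scatter) and a 1.1-fold lower number from compound 2 to compound 3 (0.05 log units; within the scatter). None of these three exchanges of the aryl group moved this assay beyond the scatter, and nothing in the data points to the naphthalen-1-yl group behaving differently. The expected step is therefore none beyond the scatter, no change at the digits printed from compound 3 to compound 4 (within the scatter). For compound 4 the estimate in this assay is 2300 nM, with a range from 1000 nM to 5500 nM.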

Compound 4, concentration for 50% growth inhibition: 2800 nM
Estimate against measurement, compound 4: 1.2-fold (0.09 log units) below, within the range that was stated.
By their numbers in this assay, from the lowest: compounds 3, 2, 1 and 4 (each within the scatter of the next).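

In this assay, naphthalen-1-yl in place of 4-bromophenyl gives a 1.2-fold higher number from compound 3 to compound 4 (0.09 log units; within the scatter), so a second six-membered aromatic ring of carbon only, with the bromine gone, still leaves the number within the scatter. The same holds against the other two groups, with a 1.1-fold higher number from compound 2 to compound 4 (0.03 log units; within the scatter) and no change at the digits printed from compound 1 to compound 4 (within the scatter), so this position on a saturated chain carbon bound to an amine nitrogen has now accepted a group of 10 heavy atoms with no step beyond the scatter among the four compounds. No measurement available here accounts for this flat response.

Going by these compounds, it remains open whether any group at this place can move the number beyond the scatter, for example an aryl group carrying a carboxylic acid or a primary amine. Also open, on these data alone, is whether a longer chain in the shared core would do so.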